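Working notes: from compound 2 to compound 3

The compounds below may be only part of what the source reports. "The series", "measured", "known", "first", "only" and "open" are said of these compounds alone.

- compound 1 `C=C1C(=O)O[C@H]2[C@H]1CC/C(Cn1cc(Cn3cc(F)c(=O)[nH]c3=O)nn1)=C\CC[C@@]1(C)O[C@@H]21`: > 20000 nM (a limit of the assay)
- compound 2 `C=C1C(=O)O[C@H]2[C@H]1CC/C(COC(=O)Cn1cc(F)c(=O)n(Cc3ccc(C(F)(F)F)cc3)c1=O)=C\CC[C@@]1(C)O[C@@H]21`: 2250 nM

For the measured compounds named here, in a functional assay on Bel-7402 cells (Homo sapiens) for antiproliferative activity, read by MTT assay, with a stated time of 72 h (on this read-out lower numbers stand for stronger inhibition and higher numbers for weaker inhibition), compound 2 gives 2250 nM, the only true number in this small set. Compound 1 stands at > 20000 nM, which is a limit and not a number.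

Compound 3 `C=C1C(=O)O[C@H]2[C@H]1CC/C(COC(=O)Cn1cc(F)c(=O)n(Cc3ccc(F)c(F)c3)c1=O)=C\CC[C@@]1(C)O[C@@H]21` is next to be measured in this assay. It differs from compound 2 as follows: 3,4-difluorophenyl in place of 4-(trifluoromethyl)phenyl on a saturated chain carbon bound to an aromatic nitrogen. In words, 3,4-difluorophenyl sits in place of 4-(trifluoromethyl)phenyl on a saturated chain carbon bound to an aromatic nitrogen.

Going by the values given here, no measured step bears on this change, so the expectation rests on compound 2 at 2250 nM, with no step beyond the usual scatter expected in either direction. The expected step is a 1.2-fold higher number from compound 2 to compound 3 (0.09 log units; within the scatter). For compound 3 the estimated value is 2800 nM, with an expected range of 900 nM to 9000 nM.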

Compound 3, half-maximal inhibitory concentration: 2700 nM
For compound 3 the middle estimate is 1.0-fold (0.02 log units) above the measured one, and the stated range covers the measured number.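

In this assay, 3,4-difluorophenyl in place of 4-(trifluoromethyl)phenyl on a saturated chain carbon bound to an aromatic nitrogen gives a 1.2-fold higher number from compound 2 to compound 3 (0.08 log units; within the scatter), the first step read at this place. This place therefore accepts the change from the group of 10 heavy atoms to the one of 8 without a step beyond the scatter, so the trifluoromethyl group is not needed to keep the number in this range. Compound 1 remains a limit of the assay, not a number, and offers no comparison here: the limit of > 20000 nM in this assay, at which 1 of the 3 values shown sits.

This single step cannot separate the loss of trifluoromethyl from the gain of the two ring fluorines. On these data alone, both groups are fluorinated phenyl rings, so it remains open how the number responds to a phenyl ring carrying an amine or a carboxylic acid, or to a longer chain in place of the saturated chain carbon.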